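The compounds below may be only part of what the source reports. "The series", "measured", "known", "first", "only" and "open" are said of these compounds alone.

Compound 1, `Cn1ccc2c(Oc3ccc(NC(=O)c4cc5cccnc5n(-c5ccc(Cl)cc5)c4=O)cc3F)ccnc21`, in a functional assay on A549 cells (Homo sapiens) for antiproliferative activity, read by MTT assay, with a stated time of 72 h; a higher number here means a weaker inhibitor, a lower number a stronger inhibitor: 350 nM
Compound 2, `Cn1ccc2c(Oc3ccc(NC(=O)c4cc5cccnc5n(-c5ccc(Br)cc5)c4=O)cc3F)ccnc21`, in this assay: 390 nM
Compound 3, `COc1ccc(-n2c(=O)c(C(=O)Nc3ccc(Oc4ccnc5c4ccn5C)c(F)c3)cc3cccnc32)cc1`, in this assay: 2750 nM

The three measured compounds share one core and differ only in the substituent on the phenyl ring attached to the aromatic nitrogen. Compound 3, carrying a methoxy group there, gives the highest number of the three in this assay: it lies a 7.9-fold higher number from compound 1 to compound 3 (0.90 log units; beyond the scatter) and a 7.1-fold higher number from compound 2 to compound 3 (0.85 log units; beyond the scatter), both gaps beyond the scatter, whereas the halogen pair sits close together, a 1.1-fold higher number from compound 1 to compound 2 (0.05 log units; within the scatter).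

Compound 4, `Cn1ccc2c(Oc3ccc(NC(=O)c4cc5cccnc5n(-c5ccc(C(F)(F)F)cc5Cl)c4=O)cc3F)ccnc21`, has not yet been measured. Its change from compound 3 is 2-chloro-4-(trifluoromethyl)phenyl in place of 4-methoxyphenyl on an aromatic nitrogen. Within the data shown here, the steps that bear on this are those from the halogenated phenyls to the methoxyphenyl, and both point the same way: replacing a halogen by methoxy raised the number modestly. Compound 4 carries two halogen-type groups and no methoxy, so the step back is expected to undo that rise. Compound 4 is therefore expected to give 400 nM in this assay, within a range of 120 nM to 1300 nM, which would mean an estimated step of a 6.9-fold lower number from compound 3 to compound 4 (0.84 log units; beyond the scatter).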

Compound 4, half-maximal inhibitory concentration: 3530 nM
For compound 4 the middle estimate is 8.8-fold (0.95 log units) below the measured one; the whole stated range lies below it.
By their numbers in this assay, from the lowest: compounds 1 and 2 (each within the scatter of the next); then compounds 3 and 4 (each within the scatter of the next).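

In this assay, the step of a 1.3-fold higher number from compound 3 to compound 4 (0.11 log units; within the scatter) puts the 2-chloro-4-(trifluoromethyl)phenyl group level with the 4-methoxyphenyl group, so at this position on the aromatic nitrogen a high number does not depend on methoxy being present. Nor does carrying halogen guarantee a low number, since the steps of a 9.1-fold higher number from compound 2 to compound 4 (0.96 log units; beyond the scatter) and a 10-fold higher number from compound 1 to compound 4 (1.00 log units; beyond the scatter) are both beyond the scatter: the low numbers of compound 1 and compound 2 belong to their single-halogen phenyl groups, and compound 4 goes against any rule that halogens alone keep the number low. No measurement is available here to explain why these phenyl groups differ.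

The chlorine and the trifluoromethyl group enter together in compound 4, so the compounds shown leave open whether one of them alone, or only the pair, goes with the higher number. They also leave open how the number would respond to an amine or a carboxylic acid on this phenyl ring, or to a longer alkyl chain there in place of the halogens.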